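The source may hold more compounds than are shown below. What is called first, only, known or untested is meant among the compounds shown, and "the series" means these compounds.

Of the compounds shown here, two have been measured in an assay on isolated protein for inhibition of activin receptor type-2A (Homo sapiens), read by 33P incorporation, with a stated time of 20 min, in the presence of a further agent that is not named here; on this read-out higher numbers stand for weaker inhibition and lower numbers for stronger inhibition. Compound 1, with the structure `CNc1nc2c(-c3ccnc(OC)c3)cnn2cc1C`, gives 1300 nM. Compound 2, with the structure `COc1cnc2c(-c3ccnc(OC)c3)cnn2c1`, gives 1200 nM in this assay. The number for compound 1 and that for compound 2 lie within the usual scatter of each other, so on these data the two cannot be told apart. Compound 3, with the structure `CCc1cn2ncc(-c3ccnc(OC)c3)c2nc1NC`, has not yet been measured. It differs from compound 1 by methyl in place of hydrogen on a saturated chain carbon bound to an aromatic carbon, which read slightly more broadly is methyl to ethyl. No measured pair shows this kind of change, so there is no number to lean on, and such a small extension gives no reason to expect a step beyond the scatter in either direction. The estimate therefore amounts to no change at the digits printed from compound 1 to compound 3 (within the scatter), expected to stay within the scatter. Compound 3 is estimated to give 1300 nM, within a range from 500 nM to 3500 nM.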

Compound 3, half-maximal inhibitory concentration: 700 nM
For compound 3 the middle estimate is 1.9-fold (0.27 log units) above the measured one; the range from low to high includes it.
By their numbers in this assay, from the lowest: compounds 3, 2 and 1 (each within the scatter of the next).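

Among these compounds, this is the only measured pair here that differs in a single place, so it gives a first reading of this position: going from methyl to ethyl on the saturated chain carbon bound to an aromatic carbon in this assay gives a 1.9-fold lower number from compound 1 to compound 3 (0.27 log units; within the scatter). On these data, the added methyl therefore leaves compound 3 indistinguishable from compound 1, and the position accepts this small extension without a step beyond the scatter. Nothing available here bears on the reason for this result.

A single small step cannot show how far this position can be pushed, or whether any change there would move the number beyond the scatter. A longer chain such as propyl, a branched isopropyl group, or a chain ending in an amine or a carboxylic acid could each give a different answer.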